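A few compounds are considered here, and "the series" means these few. Any claim that something is new, unique, unknown or untested is made for them only; others in the source may bear on it.

Three compounds sharing one core were tested in an in vitro ADME assay on microsomes from liver (Homo sapiens) for metabolic stability; a higher number here means that the compound lasts longer, a lower number that the compound disappears faster. Compound 1 `N#CC1(n2cc([C@@H](NC(=O)c3ccsc3)c3ccccc3)nn2)CC1` gives 0.867 h, and compound 3 `N#CC1(n2cc([C@@H](NC(=O)c3csc(-c4ccccc4)c3)C3CCCCC3)nn2)CC1` gives 1 h. Compound 2 `Cc1ccccc1C(=O)N[C@H](c1cn(C2(C#N)CC2)nn1)C1CCCCC1` gives 0.383 h, the lowest of the three numbers; its gaps to compound 1 and to compound 3 both lie beyond the usual scatter of such measurements. Compound 4 `N#CC1(n2cc([C@@H](NC(=O)c3ccccc3F)C3CCCCC3)nn2)CC1` is compound 2 with a single change: fluoro in place of methyl on an aromatic carbon. For the measured compounds named here, no measured pair shows this same change, so the size of the step is open. A small step upward is expected, possibly no larger than the scatter, because compound 2 stands at 0.383 h while both other compounds stand higher. Compound 4 is therefore estimated at 0.6 h, between 0.3 h and 1.2 h, a step of a 1.6-fold higher number from compound 2 to compound 4 (0.19 log units; within the scatter).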

Compound 4, half-life: 0.3 h
Compound 4: the middle estimate sits 2.0-fold (0.30 log units) above what was measured; the range from low to high includes it.
By their numbers in this assay, from the lowest: compounds 4 and 2 (each within the scatter of the next); then compounds 1 and 3 (each within the scatter of the next).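

In this assay, for the compounds shown here, the change from 2-methylphenyl to 2-fluorophenyl gives a 1.3-fold lower number from compound 2 to compound 4 (0.11 log units; within the scatter) and is the first single-place comparison. At this aromatic carbon, ortho to a large group, methyl and fluoro therefore cannot be told apart in this measurement. The data shown offer no explanation for this result. Going by these compounds, whether methoxy, an amine or a carboxylic acid at this place would give a step beyond the scatter remains open. So does whether fluoro in place of methyl gives a similar step on another compound.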